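Hydrogen for methyl on the ring: clearance expectation

A few compounds are considered here, and "the series" means these few. Any claim that something is new, unique, unknown or untested is made for them only; others in the source may bear on it.

Measured in an ADME assay on liver for metabolic stability, with Liver microsome (Rattus norvegicus) as the target, read by LC-MS, using microsomes, with a stated time of 5 h; on this read-out lower numbers stand for slow clearance and higher numbers for fast clearance:
compound 1 `C[C@]1(O)C[C@](c2cccc(C(F)(F)F)c2)([C@H](O)c2ccccn2)C1` gives 66.7 mL/min/kg
compound 2 `O[C@H](c1ccccn1)[C@]1(c2cccc(C(F)(F)F)c2)C[C@H](O)C1` gives 183 mL/min/kg
compound 3 `C[C@]1(O)C[C@](c2ccnc(C(F)(F)F)c2)([C@H](O)c2ccccn2)C1` gives 83.3 mL/min/kg

Compound 4 `O[C@H](c1ccccn1)[C@]1(c2ccnc(C(F)(F)F)c2)C[C@H](O)C1` is not yet measured in this assay. Compound 4 differs from compound 3 by hydrogen in place of methyl on a saturated ring carbon. The same kind of change separates compound 2 from compound 1: hydrogen in place of methyl on a saturated ring carbon. Both "place" descriptions are the same word for word. In this assay that step made a 2.7-fold higher number from compound 1 to compound 2 (0.44 log units; beyond the scatter). The difference between the two cores, compound 1 and compound 3, is not broken down here; their values lie within the scatter of each other. Within the data shown here, because the step of a 2.7-fold higher number from compound 1 to compound 2 (0.44 log units; beyond the scatter) is the only precedent, compound 4 is expected to show a step of a 2.7-fold higher number from compound 3 to compound 4 (0.43 log units; beyond the scatter). Compound 4 is therefore estimated at 225 mL/min/kg, between 110 mL/min/kg and 450 mL/min/kg.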

Compound 4, clearance: 50 mL/min/kg
The estimate for compound 4 lay 4.5-fold (0.65 log units) above the measured number; measured number outside the range, below it.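

In this assay, hydrogen in place of methyl on a saturated ring carbon gives a 1.7-fold lower number from compound 3 to compound 4 (0.22 log units; within the scatter), a step that cannot be told from the scatter on the core of compound 3. Among these compounds, the same change did not carry over unchanged between the two cores, and the two steps differ by more than repeated measurements would account for: the same change on two cores in this assay, a 2.7-fold higher number (0.44 log units; beyond the scatter) from compound 1 to compound 2 and a 1.7-fold lower number (0.22 log units; within the scatter) from compound 3 to compound 4, 4.6-fold (0.66 log units) apart, beyond the scatter of two such steps This shows that the step measured on one core could not be transferred to the other, but with only two pairs it does not show which difference between the cores matters. The compounds shown leave open how the change behaves on any further core. As far as these compounds go, it also remains open whether a nitrile or an amine in place of the trifluoromethyl group would follow either step.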